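The source may hold more compounds than are shown below. What is called first, only, known or untested is meant among the compounds shown, and "the series" means these compounds.

Compound 1 `Cc1cc(Nc2nc(Nc3ccc(C(=O)NC4CC(C)(C)N([O])C(C)(C)C4)cc3)ncc2[N+](=O)[O-])n[nH]1` and compound 2 `Cc1cc(Nc2nc(Nc3ccc(C(=O)NC4CC(C)(C)N([O])C(C)(C)C4)cc3)ncc2F)n[nH]1` share one core and differ at a single aromatic carbon, where compound 1 carries a nitro group and compound 2 a fluorine. In a functional assay on HepG2 cells (Homo sapiens) for antiproliferative activity, read by MTT assay, with a stated time of 48 h (a higher number here means a weaker inhibitor, a lower number a stronger inhibitor), compound 1 gives 37500 nM, and compound 2 gives 10800 nM; the move between them is a 3.5-fold lower number from compound 1 to compound 2 (0.54 log units; beyond the scatter). Compound 2 therefore holds the lower of the two numbers seen so far. Compound 3 `CCCCOC(=O)Cc1cc(Nc2nc(Nc3ccc(C(=O)NC4CC(C)(C)N([O])C(C)(C)C4)cc3)ncc2F)n[nH]1` keeps the fluorine of compound 2 and differs from it elsewhere: butoxycarbonyl in place of hydrogen on a saturated chain carbon bound to an aromatic carbon. For the measured compounds named here, no measured step touches this place; the only step recorded concerns the nitro-to-fluoro exchange and says nothing about the chain. Without a matching precedent, neither size nor direction can be read from the numbers, so compound 3 is expected to land near compound 2, with no change beyond the scatter as the most likely outcome. The expected step is a 1.1-fold lower number from compound 2 to compound 3 (0.03 log units; within the scatter), with wide uncertainty. For compound 3 the estimate is 10000 nM, ranging from 2500 nM to 40000 nM.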

Compound 3, half-maximal inhibitory concentration: 5730 nM
Estimate against measurement, compound 3: 1.7-fold (0.24 log units) above; the range from low to high includes it.
By their numbers in this assay, from the lowest: compounds 3 and 2 (each within the scatter of the next); then compound 1.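

Measured in this assay the new group gives a 1.9-fold lower number from compound 2 to compound 3 (0.28 log units; within the scatter) and so leaves compound 3 and compound 2 indistinguishable in this read-out. For the compounds shown here, the earlier step spoke only of the aromatic carbon that carries nitro or fluoro, whereas this pair is the first look at the other end of the molecule: methyl can become (butoxycarbonyl)methyl, a much larger group, without a change beyond the scatter. No independent measurement is available to explain this result.

On these data alone, one pair cannot show whether this position is generally indifferent to what it carries, so it remains open whether a carboxylic acid, an amine or a longer chain at this place would give a similar number. As far as these compounds go, it is equally open whether butoxycarbonyl would behave the same way alongside nitro instead of fluoro.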